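The source may hold more compounds than are shown below. What is called first, only, known or untested is meant among the compounds shown, and "the series" means these compounds.

Compound 1 `O=C(Nc1cc(-c2ccccc2)nn1-c1ccccn1)c1ccccc1` in an assay on HEK293 cells for displacement of a labelled ligand from metabotropic glutamate receptor 5 (Rattus norvegicus) (on this read-out higher numbers stand for weaker inhibition and lower numbers for stronger inhibition), gives > 10000 nM, a limit of the assay.
Compound 2 `N#Cc1cccc(-n2nc(-c3ccccc3)cc2NC(=O)c2ccccc2)c1` in this assay gives > 10000 nM, also a limit of the assay.

Neither value is a number: the limit of > 10000 nM in this assay, at which 2 of the 2 values shown sit. The step that the two limits leave unreadable from compound 1 to compound 2 cannot be read because of the limit of > 10000 nM in this assay, at which 2 of the 2 values shown sit. Compound 2 therefore stands only at a limit in this assay, and how far beyond that limit its true inhibition constant lies is not shown by the data.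

Compound 3 `COc1cccc(-n2nc(-c3ccccc3)cc2NC(=O)c2ccccc2)c1` differs from compound 2 by methoxy in place of cyano on an aromatic carbon. Among the compounds with values here, no measured step touches this part of the molecule: the only measured step changes the group on the aromatic nitrogen, and its size is unreadable. Nothing in the measured pairs thus points to a direction for the methoxy in place of cyano, and the most that can be drawn from two limits is that compound 3 is expected to sit near the same limit, with a fair chance that this assay again reports only a limit.

Compound 3 is expected at 10000 nM, with a range from 3000 nM to 30000 nM. This estimate means a step of a number no higher from compound 2 to compound 3 (the limit leaves the size open), that is, none beyond the scatter.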

Compound 3, inhibition constant: 2100 nM
Estimate against measurement, compound 3: 4.8-fold (0.68 log units) above; the measured number lies below the stated range.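

Replacing the nitrile with a methoxy group on the phenyl ring gives the only true number among the compounds shown in this assay, and the change is an at least 4.7-fold lower number from compound 2 to compound 3 (0.67 log units; beyond the scatter). Set against the pyridin-2-yl group on the aromatic nitrogen, the 3-methoxyphenyl group gives an at least 4.7-fold lower number from compound 1 to compound 3 (0.67 log units; beyond the scatter), so the group on this ring can change the result, something the earlier pair could not show, even though cyano and methoxy have the same count of heavy atoms and of hydrogen-bond acceptors. Both sizes are minimums, and the step between the other two compounds cannot be read, because neither of them gives a number: the limit of > 10000 nM in this assay, at which 2 of the 3 values shown sit.

The compounds shown leave open how the number would move with a longer chain such as ethoxy, with an amine such as dimethylamino, or with a single chlorine atom at the same place on the ring. They also leave open whether the methoxy group would give a similar result on another carbon of that ring, and whether a change elsewhere on the shared core would matter.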